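This account rests on a few compounds, and the source may have more. Where it says the series, first, only, none or still open, it means among the compounds named here.

Measured in an ADME assay on liver for metabolic stability, with Liver microsome (Homo sapiens) as the target, read by LC-MS, using microsomes; on this read-out lower numbers stand for slow clearance and higher numbers for fast clearance:

- compound 1 `O=C(NCc1cc(Cl)ccc1-n1cnnn1)[C@@H]1C[C@@H]2C[C@@H]2N1C(=O)[C@H](O)Cn1cccn1`: < 12 mL.min-1.g-1, which is a limit of the assay and not a number
- compound 2 `CC(C)(C)C[C@@H](O)C(=O)N1N=CC[C@H]1C(=O)NCc1cc(Cl)ccc1-n1cnnn1`: 22 mL.min-1.g-1
- compound 3 `O=C(NCc1cc(Cl)ccc1-n1cnnn1)[C@@H]1C[C@@H]2C[C@@H]2N1C(=O)[C@H](O)C1CCCCC1`: 150 mL.min-1.g-1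

Compound 3 has the highest number measured, at 150 mL.min-1.g-1. The nearest number belongs to compound 2, at 22 mL.min-1.g-1, which is lower by more than the usual scatter.

Compound 4 `CC(C)(C)C[C@@H](O)C(=O)N1[C@H](C(=O)NCc2cc(Cl)ccc2-n2cnnn2)C[C@@H]2C[C@@H]21` keeps the core of compound 3 but carries neopentyl in place of cyclohexyl on a saturated chain carbon bound to a carbonyl carbon and an oxygen on a saturated carbon.

Going by the values given here, only one measured step involves this place, an at least 12-fold higher number from compound 1 to compound 3 (1.09 log units; beyond the scatter). It shows that a change here can move the number a long way, but it is a different exchange, so it gives no direct size for this one. A second clue is that compound 2 already carries neopentyl, on a different core, and sits at 22 mL.min-1.g-1. A moderate fall is therefore expected, smaller than the measured step. The expected step is a 2.5-fold lower number from compound 3 to compound 4 (0.40 log units; beyond the scatter). For compound 4 the estimated value is 60 mL.min-1.g-1, within an expected range of 25 mL.min-1.g-1 to 130 mL.min-1.g-1.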

Compound 4, intrinsic clearance in microsomes: 40 mL.min-1.g-1
Beside the measured number, compound 4's estimate is 1.5-fold (0.18 log units) above it, and the stated range covers the measured number.
By their numbers in this assay, from the lowest: compounds 2 and 4 (each within the scatter of the next); then compound 3. At a limit, below all of these: compound 1.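

In this assay, neopentyl in place of cyclohexyl on a saturated chain carbon bound to a carbonyl carbon and an oxygen on a saturated carbon gives a 3.8-fold lower number from compound 3 to compound 4 (0.57 log units; beyond the scatter), so opening the carbon ring is not neutral at this position. Neopentyl still does not match the (1H-pyrazol-1-yl)methyl group of compound 1, since tert-butyl in place of 1H-pyrazol-1-yl gives an at least 3.3-fold higher number from compound 1 to compound 4 (0.52 log units; beyond the scatter), which leaves both all-carbon groups on the higher side of compound 1. Compound 1 stands at a limit, not a number, so that step has no upper size: the limit of < 12 mL.min-1.g-1 in this assay, at which 1 of the 4 values shown sits.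

The compounds shown cannot separate the loss of the ring from the loss of one carbon. As far as these compounds go, how an isopropyl group or a chain ending in an amine would read at this position also stays open.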